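Shortening the selenocyanate side chain of compound 2

The source may hold more compounds than are shown below. What is called first, only, known or untested is meant among the compounds shown, and "the series" means these compounds.

Compound 1 `COc1ccc(N(C)c2nc(C)nc3ccccc23)cc1[Se]C`: 10 nM
Compound 2 `COc1ccc(N(C)c2nc(C)nc3ccccc23)cc1C(=O)OCCCC[Se]C#N`: 554 nM

Both compounds were tested in a functional assay on MDA-MB-231 cells (Homo sapiens) for inhibition, read by MTT assay, with a stated time of 48 h; a lower number here means a stronger inhibitor, a higher number a weaker inhibitor. Compound 2 gives 554 nM, the higher of the two numbers, which makes it the weaker inhibitor of the pair. Compound 3 `COc1ccc(N(C)c2nc(C)nc3ccccc23)cc1OCC[Se]C#N` keeps the shared core and differs from compound 2 on an aromatic carbon, ortho to a methoxy group: a group of 6 heavy atoms (3 carbon, 1 nitrogen, 1 oxygen, 1 selenium; no ring) in place of a group of 10 heavy atoms (6 carbon, 1 nitrogen, 2 oxygen, 1 selenium; no ring), on an aromatic carbon. For the measured compounds named here, only one measured step bears on this change. Its size is large, and it came with a group of 10 heavy atoms in place of a group of 2 heavy atoms. The entering group of 6 heavy atoms falls between those two sizes, so only part of the step of a 55-fold higher number from compound 1 to compound 2 (1.74 log units; beyond the scatter) is expected to be undone. That single step cannot show that size alone matters, so the expectation is loose. A moderate fall in the number is expected: a 3.7-fold lower number from compound 2 to compound 3 (0.57 log units; beyond the scatter). For compound 3 the estimated value is 150 nM, with an expected range of 30 nM to 700 nM.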

Compound 3, half-maximal inhibitory concentration: 13 nM
Beside the measured number, compound 3's estimate is 12-fold (1.06 log units) above it; measured number below the stated range.
By their numbers in this assay, from the lowest: compounds 1 and 3 (each within the scatter of the next); then compound 2.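

In this assay, the step of a 43-fold lower number from compound 2 to compound 3 (1.63 log units; beyond the scatter) shows that a selenocyanate chain on this aromatic carbon does not by itself bring a high number. The earlier pair left room for any group much larger than the small selenium group of compound 1 to cost heavily, but a 1.3-fold higher number from compound 1 to compound 3 (0.11 log units; within the scatter) places the two compounds within the scatter of each other, so a group of 6 heavy atoms can match a group of 2 heavy atoms here. For the compounds shown here, nothing available explains why the group in compound 3 fares so much better than the one in compound 2.

The change from compound 2 to compound 3 both shortens the chain and removes the carbonyl, so the two effects remain tangled. A carbonyl-linked chain as short as that of compound 3, or an oxygen-linked chain as long as that of compound 2, would begin to separate them.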